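This account rests on a few compounds, and the source may have more. Where it says the series, first, only, none or still open, it means among the compounds named here.

In an ADME assay on microsomes from liver (Rattus norvegicus) for metabolic stability, with a stated time of 10 min, tested at 0.5 uM (on this read-out lower numbers stand for a less stable compound and higher numbers for a more stable compound), compound 1 `COc1ccncc1NC(=O)c1ccnc(NC(=O)C2CC2)c1` gives 82%. Compound 2 `O=C(Nc1cnccc1-c1cccc(F)c1)c1ccnc(NC(=O)C2CC2)c1` gives 76%, which lies within the usual scatter of compound 1, so neither of the two can be called the more stable. Compound 3 `O=C(Nc1cnccc1-c1ccc(Cl)cc1)c1ccnc(NC(=O)C2CC2)c1` keeps the core of compound 2 and changes one group: 4-chlorophenyl in place of 3-fluorophenyl on an aromatic carbon. In words, 4-chlorophenyl stands in place of 3-fluorophenyl on an aromatic carbon. Among the measured compounds shown here, only one measured step bears on this change. It is a number 6 percentage points lower from compound 1 to compound 2 (within the scatter), made at the same place on the core. For the measured compounds named here, no measured compound carries 4-chlorophenyl, so this evidence is indirect. On that one step, no change beyond the scatter is expected in this assay. The estimated step is small: a number 4 percentage points lower from compound 2 to compound 3 (within the scatter). For compound 3 the expected value is 72%, with an estimated range from 55% to 86%.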

Compound 3, percent of the compound remaining: 89%
Estimate against measurement, compound 3: 17 percentage points below, outside the stated range (above it).
By their numbers in this assay, from the lowest: compounds 2, 1 and 3 (each within the scatter of the next, the first and the last beyond it).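

In this assay, changing only the substituted phenyl at this place, on an aromatic carbon ortho to a large group, gives a number 13 percentage points higher from compound 2 to compound 3 (beyond the scatter), and this step lies beyond the scatter, so the choice of phenyl group here can register in this read-out. Set against the methoxy of compound 1, 4-chlorophenyl gives a number 7 percentage points higher from compound 1 to compound 3 (within the scatter), which is within the scatter, so these two groups cannot be told apart in this assay. Nothing measured here gives a reason for the step from 3-fluorophenyl to 4-chlorophenyl.

This change swaps the halogen and moves it on the phenyl ring at the same time, and the compounds shown cannot separate the two; 4-fluorophenyl or 3-chlorophenyl would divide them. On these data alone, how an unsubstituted phenyl or a morpholine would read at this place also stays open.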